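Fluorine on the amide ring of a cytosine-bearing butenyl benzamide

The source may hold more compounds than are shown below. What is called first, only, known or untested is meant among the compounds shown, and "the series" means these compounds.

Three compounds sharing a benzamide joined through an unsaturated four-carbon linker to a pyrimidinone base have been examined in a functional assay on HEp-2 cells (Homo sapiens) for cytotoxicity, read by MTT assay, with a stated time of 72 h; a lower number here means a stronger inhibitor, a higher number a weaker inhibitor. Compound 1 `O=C(NC/C=C\Cn1ccc(=O)[nH]c1=O)c1ccccc1` reaches only the limit of the assay, > 100000 nM. Compound 2 `O=C(NC/C=C\Cn1cc(F)c(=O)[nH]c1=O)c1ccccc1` gives 87500 nM in this assay. The change between them is fluoro in place of hydrogen on an aromatic carbon, and the step is an at least 1.1-fold lower number from compound 1 to compound 2 (0.05 log units; that floor lies within the scatter). Compound 3 `Nc1ccn(C/C=C\CNC(=O)c2ccccc2)c(=O)n1` likewise reaches only the limit of the assay, > 100000 nM. How the core of compound 3 differs from that of compound 1 is not broken down here.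

Compound 4 `Nc1ccn(C/C=C\CNC(=O)c2ccc(F)cc2)c(=O)n1` is not yet measured in this assay. It differs from compound 3 by fluoro in place of hydrogen on an aromatic carbon, the same kind of change as that between compound 1 and compound 2, though the place differs: in compound 2 the fluoro sits on a six-membered aromatic ring with 2 nitrogen, ortho to a group of 1 heavy atom, two atoms from the ring nitrogen, meta to a large group and para to a group of 1 heavy atom, whereas in compound 4 it sits on a six-membered aromatic ring of carbon only, para to a large group. The step from compound 3 to compound 4 is expected to be a step that the limit leaves unreadable from compound 3 to compound 4, resting on an at least 1.1-fold lower number from compound 1 to compound 2 (0.05 log units; that floor lies within the scatter) and on (the limit of > 100000 nM in this assay, at which 2 of the 3 values shown sit). Compound 4 is therefore estimated at 150000 nM in this assay.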

Compound 4, half-maximal inhibitory concentration: > 100000 nM
Compound 4 gave a limit, no number; the forecaster's own chance of this, stated with the estimate: 85%; the middle value lies beyond the limit too.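

In this assay compound 3 and compound 4 both end at a limit of the assay and not at a number, so no step can be read between them: the limit of > 100000 nM in this assay, at which 3 of the 4 values shown sit. The compounds shown leave open whether the change from phenyl to 4-fluorophenyl on this core alters the read-out at all.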